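Moving the hydroxy group: compound 3 to compound 4

A few compounds are considered here, and "the series" means these few. Any claim that something is new, unique, unknown or untested is made for them only; others in the source may bear on it.

In an ADME assay on microsomes from liver (Rattus norvegicus) for metabolic stability, read by LC-MS, with a stated time of 30 min, tested at 0.5 uM (on this read-out lower numbers stand for a less stable compound and higher numbers for a more stable compound), compound 1 `c1ccc(-c2cc(-c3csc(N=C4NCCCN4)n3)cs2)cc1` gives 30% and compound 2 `c1ccc(-c2nc(-c3csc(N=C4NCCCN4)n3)cs2)cc1` gives 31%. Compound 3 `Oc1ccc(-c2nc(-c3csc(N=C4NCCCN4)n3)cs2)cc1` stands highest of the three at 53%. Compound 4 `Oc1cccc(-c2nc(-c3csc(N=C4NCCCN4)n3)cs2)c1` has the same atoms joined differently: 3-hydroxyphenyl in place of 4-hydroxyphenyl on an aromatic carbon. For the measured compounds named here, the one measured step that bears on this change is a number 22 percentage points higher from compound 2 to compound 3 (beyond the scatter), with hydroxy in place of hydrogen on an aromatic carbon. Going by the values given here, no measured compound shows what a different hydroxy position does in this assay. Compound 4 still carries a hydroxy group, so only a small downward move is expected. The expected change is a number 7 percentage points lower from compound 3 to compound 4 (within the scatter). Compound 4 is estimated at 46%, with an expected range of 30% to 62%.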

Compound 4, percent of the compound remaining: 35%
Compound 4: middle estimate off by 11 percentage points, on the high side, within the range that was stated.
By their numbers in this assay, from the lowest: compounds 1, 2 and 4 (each within the scatter of the next); then compound 3.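

In this assay the hydroxy position counts: the change to 3-hydroxyphenyl gives a number 18 percentage points lower from compound 3 to compound 4 (beyond the scatter) and so takes back most of the earlier gain. Hydroxy in place of hydrogen now gives only a number 4 percentage points higher from compound 2 to compound 4 (within the scatter) and the rise seen for compound 3 belongs, among these compounds, to 4-hydroxyphenyl alone. Nothing at hand explains the difference between the two hydroxyphenyl groups. The compounds shown do not tell whether the rise needs a hydroxy group at all. 4-Methoxyphenyl or 4-aminophenyl in place of 4-hydroxyphenyl would bear on that question.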